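Mirror-image test at the low end of three values

The compounds below may be only part of what the source reports. "The series", "measured", "known", "first", "only" and "open" are said of these compounds alone.

- compound 1 `COc1cc([C@@H]2C[C@@]2(CO)C(=O)Nc2ccccc2)cc(OC)c1OC` at 43200 nM
- compound 2 `CCOC(=O)[C@]1(C(=O)Nc2ccccc2)C[C@H]1c1cc(OC)c(OC)c(OC)c1` at 37300 nM
- compound 3 `CCOC(=O)[C@]1(C(=O)Nc2ccccc2)C[C@@H]1c1cc(OC)c(OC)c(OC)c1` at 21300 nM

All three numbers come from a functional assay on A549 cells (Homo sapiens) for cytotoxicity, read by MTT assay, with a stated time of 48 h; on this read-out higher numbers stand for weaker inhibition and lower numbers for stronger inhibition. Compound 3 sits at the low end of this small set, clearly apart from compound 1 but level with compound 2 within the scatter. The next compound to be tested is compound 4 `CCOC(=O)[C@@]1(C(=O)Nc2ccccc2)C[C@H]1c1cc(OC)c(OC)c(OC)c1`. Nothing leaves and nothing enters on the way from compound 3, since only the spatial arrangement changes: the two compounds have the same atoms and bonds and differ only in configuration as drawn: 2 of 2 stereo elements differ (all stereocentres are inverted: mirror images); a stereocentre at a saturated ring carbon is drawn R in compound 3 and S in compound 4; a stereocentre at a saturated ring carbon is drawn R in compound 3 and S in compound 4. Compound 4 is therefore the mirror image of compound 3.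

Among the compounds with values here, one measured step bears on this, namely a 1.8-fold lower number from compound 2 to compound 3 (0.24 log units; within the scatter). It is the closest guide given (the fact that compounds 2 and 3 differ only in the configuration as drawn), and it shows that changing the configuration at one centre moved the number by no more than the usual scatter. Within the data shown here, it is only a partial guide, as both centres are inverted in compound 4 and only one differed in that step. On that evidence, no step beyond the scatter is expected in this assay, and no firm direction either. The expected step is a 1.3-fold higher number from compound 3 to compound 4 (0.12 log units; within the scatter) and this small rise only reflects the higher values of the two other compounds. Compound 4 is estimated at 28000 nM with an expected range from 14000 nM to 52000 nM.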

Compound 4, half-maximal inhibitory concentration: 65900 nM
Estimate against measurement, compound 4: 2.4-fold (0.37 log units) below, outside the stated range (above it).
By their numbers in this assay, from the lowest: compounds 3, 2, 1 and 4 (each within the scatter of the next, the first and the last beyond it).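

The mirror-image pair shows that spatial arrangement alone can separate two compounds in this assay, with a 3.1-fold higher number from compound 3 to compound 4 (0.49 log units; beyond the scatter), and nothing but that arrangement distinguishes them: the fact that compounds 3 and 4 differ only in the configuration as drawn Inverting one centre at a time does not give a step of that size, since a 1.8-fold lower number from compound 2 to compound 3 (0.24 log units; within the scatter) and a 1.8-fold higher number from compound 2 to compound 4 (0.25 log units; within the scatter) both stay within the scatter, so in this small set only the inversion of both centres goes beyond it. The group on the saturated ring carbon does not separate compounds with this configuration, as ethoxycarbonyl in place of hydroxymethyl gives a 1.5-fold higher number from compound 1 to compound 4 (0.18 log units; within the scatter), which is also within the scatter.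

Going by these compounds, it remains open whether the mirror-image gap would also appear with hydroxymethyl on that ring carbon, or with a carboxylic acid or an amine there. These compounds also cannot show whether the same gap would hold in this assay with a different group in place of the phenyl on the amide, such as a longer alkyl chain.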